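The compounds below may be only part of what the source reports. "The series", "measured", "known", "first", "only" and "open" are said of these compounds alone.

Measured in a functional assay on brain (Rattus norvegicus, strain Wistar) for inhibition; a higher number here means a weaker inhibitor, a lower number a stronger inhibitor:
- compound 1 `CCCCn1c(-c2ccccc2)c(C)[nH]c1=O`: > 100000 nM
- compound 2 `COc1ccc(-c2c(C)[nH]c(=O)n2C)cc1`: 147000 nM

The entry for compound 1, > 100000 nM, is a limit of the assay and not a number. Among the measured compounds shown here, compound 2, at 147000 nM, therefore holds the only actual number in this assay so far. Compound 3 `CCCCCOc1ccc(-c2c(C)[nH]c(=O)n2C)cc1` keeps the core of compound 2 and differs in one place: butyl in place of hydrogen on a saturated chain carbon bound to an oxygen on an aromatic ring, which turns methoxy into pentyloxy. For the measured compounds named here, no measured pair here shows what such a change does, so the expectation is tentative. A moderate gain in strength, beyond the scatter, is expected. The expected step, a 3.7-fold lower number from compound 2 to compound 3 (0.57 log units; beyond the scatter), points to a lower number, though a limit reading remains possible. For compound 3 the estimate is 40000 nM, with an expected range of 8000 nM to 150000 nM.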

Compound 3, half-maximal inhibitory concentration: 4500 nM
Compound 3: middle estimate off by 8.9-fold (0.95 log units), on the high side, outside the stated range (below it).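

In this assay, the change from methoxy to pentyloxy gives a 33-fold lower number from compound 2 to compound 3 (1.51 log units; beyond the scatter), which shows that the saturated chain carbon bound to an oxygen on an aromatic ring is a place where added butyl has a large effect on the reading. Among the compounds shown here, this is the only readable step, and it shows that the shared core can reach a number well away from the weak values seen with compound 2 alone. Compound 1 remains a limit of the assay and not a number, and it provides no step: the limit of > 100000 nM in this assay, at which 1 of the 3 values shown sits.

This single step leaves open whether the gain builds gradually along the chain or continues with a longer chain such as octyloxy. It also leaves open how an amine or a carboxylic acid at the end of the pentyl chain would read.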